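A single bromo added to compound 3

This account rests on a few compounds, and the source may have more. Where it says the series, first, only, none or still open, it means among the compounds named here.

Measured so far in a functional assay on SK-N-SH cells (Homo sapiens) for cytotoxicity, read by MTT assay, with a stated time of 24 h (a lower number here means a stronger inhibitor, a higher number a weaker inhibitor), are these compounds:
compound 1 `O=c1nc2ccc(Br)cn2cc1Cc1ccc(Br)cc1` with 870 nM as its value
compound 2 `O=c1nc2ccccn2cc1Cc1ccc(F)cc1` with 125000 nM as its value
compound 3 `O=c1nc2ccccn2cc1Cc1ccccc1` with 95400 nM as its value

Compound 3 sits within the scatter of compound 2 at the high end of these numbers, and compound 1 gives a far lower number. Compound 4 `O=c1nc2ccccn2cc1Cc1ccc(Br)cc1` is compound 3 with one change: bromo in place of hydrogen on an aromatic carbon at the place para to a large group. Among the compounds with values here, the one measured step at that place is a 1.3-fold lower number from compound 2 to compound 3 (0.12 log units; within the scatter) and shows that fluoro and hydrogen cannot be told apart there. Compound 1 at 870 nM does carry the same bromo, but it has a further bromo on its core, and the data do not separate the two. Only part of the gap to compound 1 is therefore expected here. The estimated step is an 8.0-fold lower number from compound 3 to compound 4 (0.90 log units; beyond the scatter) in this assay as a clear move towards lower numbers. Compound 4 is expected at 12000 nM within an estimated range of 2000 nM to 70000 nM when measured.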

Compound 4, half-maximal inhibitory concentration: 163000 nM
For compound 4 the middle estimate is 14-fold (1.13 log units) below the measured one; measured number above the stated range.
By their numbers in this assay, from the lowest: compound 1; then compounds 3, 2 and 4 (each within the scatter of the next).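

In this assay, the place para to a large group now carries hydrogen, fluoro or bromo, and the size of the incoming halogen brings no step beyond the scatter there (a 1.7-fold higher number from compound 3 to compound 4 (0.23 log units; within the scatter); a 1.3-fold higher number from compound 2 to compound 4 (0.12 log units; within the scatter)). The bromo at that place therefore does not by itself give a low number, and the large gap falls to the one remaining difference, the bromo on the core of compound 1 (a 190-fold higher number from compound 1 to compound 4 (2.27 log units; beyond the scatter)). Nothing measured here explains why that core bromo matters so much.

The compounds shown leave open whether the core bromo keeps its effect with hydrogen or fluoro, rather than bromo, at the place para to a large group. They also leave open whether chloro, an amine or a carboxylic acid on the core would do the same.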